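Rearranging One Side Chain on a Shared Core

This account rests on a few compounds, and the source may have more. Where it says the series, first, only, none or still open, it means among the compounds named here.

Of the compounds shown here, three have been measured so far in a functional assay for inhibition, with Rattus norvegicus as the target; on this read-out higher numbers stand for weaker inhibition and lower numbers for stronger inhibition. Compound 1 `CC(/N=c1\c(O)c(O)\c1=N/c1ccc(Br)cc1)C(C)(C)C` gives 1260 nM, compound 2 `COc1ccc(Nc2c(NC(C)C(C)(C)C)c(=O)c2=O)cc1` gives 2400 nM, and compound 3 `CC(C)C(C)/N=c1\c(O)c(O)\c1=N/c1ccc(C#N)cc1` gives 1900 nM. Compound 3 lies within the usual scatter of both others, so these numbers set no firm ranking around it. Compound 4 `CCC(C)(C)/N=c1\c(O)c(O)\c1=N/c1ccc(C#N)cc1` is still unmeasured. It carries 1,1-dimethylpropyl in place of 1,2-dimethylpropyl on a double-bonded nitrogen, so the same atoms are joined differently. For the measured compounds named here, no measured pair shows a change of this kind, which leaves no direct guide. The expected step, a 1.2-fold lower number from compound 3 to compound 4 (0.07 log units; within the scatter), is none beyond the scatter. The estimate for compound 4 is 1600 nM, with an expected range of 550 nM to 4500 nM.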

Compound 4, half-maximal inhibitory concentration: > 30000 nM
Compound 4 ended at the assay's limit; the forecaster's own chance of this, stated with the estimate: 5%; at least 18-fold (1.27 log units) between middle value and limit.
By their numbers in this assay, from the lowest: compounds 1, 3 and 2 (each within the scatter of the next). At a limit, above all of these: compound 4.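

On a double-bonded nitrogen, joining the same atoms differently is enough to change the result: 1,1-dimethylpropyl in place of 1,2-dimethylpropyl gives an at least 15-fold higher number from compound 3 to compound 4 (1.19 log units; beyond the scatter) in this assay. Compound 4 stands at > 30000 nM, which is a limit of the assay and not a number: the limit of > 30000 nM in this assay, at which 1 of the 4 values shown sits. The earlier compounds shown here formed no pair differing in one place, so only now does this position prove sensitive to how its side chain is joined.

The reason for this sensitivity stays open. So does how a straight pentyl chain, or a side chain carrying an amine, would behave on this nitrogen.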